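Shortening an Ethoxy Chain on a Weakly Cytotoxic Thiazolidinone

This account rests on a few compounds, and the source may have more. Where it says the series, first, only, none or still open, it means among the compounds named here.

Compound 1 `Nc1nccnc1C(=O)NN1C(=O)CSC1c1ccccc1`: 89.7 ug/mL
Compound 2 `CCOc1cc([C@@H]2SCC(=O)N2NC(=O)c2cnc(C)cn2)ccc1O`: > 100 ug/mL

Compound 1 `Nc1nccnc1C(=O)NN1C(=O)CSC1c1ccccc1` was tested in an ADME assay on THP-1 cells (Homo sapiens) for cytotoxicity, read by MTT assay, with a stated time of 5 days (on this read-out higher numbers stand for weaker inhibition and lower numbers for stronger inhibition), and compound 1 gives 89.7 ug/mL. Compound 2 `CCOc1cc([C@@H]2SCC(=O)N2NC(=O)c2cnc(C)cn2)ccc1O` reaches only a limit of the assay in this assay, with compound 2 at > 100 ug/mL. This is the limit of > 100 ug/mL in this assay, at which 1 of the 2 values shown sits, so where compound 2 truly stands is not known as a number.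

Compound 3 `COc1cc([C@@H]2SCC(=O)N2NC(=O)c2cnc(C)cn2)ccc1O` differs from compound 2 in one place: hydrogen in place of methyl on a saturated chain carbon bound to an oxygen on an aromatic ring. The expected step in this assay is none beyond the scatter, so the estimate for compound 3 amounts to a step that the limit leaves unreadable from compound 2 to compound 3. Compound 3 is expected at 110 ug/mL, within 55 ug/mL to 220 ug/mL.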

Compound 3, half-maximal inhibitory concentration: 86.9 ug/mL
Compound 3: middle estimate off by 1.3-fold (0.10 log units), on the high side; the range from low to high includes it.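

Going from ethoxy to methoxy gives an at least 1.1-fold lower number from compound 2 to compound 3 (0.06 log units; that floor lies within the scatter) in this assay. Compound 3 gives this position its first actual number, where the ethoxy compound offered none. Going by these compounds, the real size of the step stays unknown because compound 2 stands at a limit of the assay: the limit of > 100 ug/mL in this assay, at which 1 of the 3 values shown sits.

On these data alone, whether this position tolerates other groups remains open. A longer chain such as propyl, or an amine or a carboxylic acid on that chain, could move the number beyond the scatter or leave it unchanged.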